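This account rests on a few compounds, and the source may have more. Where it says the series, first, only, none or still open, it means among the compounds named here.

Of the compounds shown here, three built on one shared core have been tested in a functional assay on the whole organism (strain NMRI) with Mus musculus as the target, with a stated time of 60 min, at a dose of 5 mg/kg by the intraperitoneal route; a higher number here means a stronger effect of the compound at the dose given, a lower number a weaker effect. Compound 1 `CCCSc1nnc(Cc2ccc(Cl)cc2Oc2ccccc2Cl)[nH]1` gives 118% in this assay. Compound 2 `Clc1ccc(Cc2nnc(SCc3ccccc3)[nH]2)c(Oc2ccccc2Cl)c1` differs from compound 1 by phenyl in place of ethyl on a saturated chain carbon bound to a sulfur; in this assay compound 2 gives 113%. Compound 3 `CCCSc1nnc(Cc2ccc(Cl)cc2Oc2ccccc2F)[nH]1` differs from compound 1 in the core itself, by fluoro in place of chloro on an aromatic carbon; in this assay compound 3 gives 119%, and the step is a number 1 percentage points higher from compound 1 to compound 3 (within the scatter). All three numbers lie within the usual scatter of one another, so they are not told apart here.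

Compound 4 `Fc1ccccc1Oc1cc(Cl)ccc1Cc1nnc(SCc2ccccc2)[nH]1` has not yet been measured. It stands to compound 3 exactly as compound 2 stands to compound 1: the change is phenyl in place of ethyl on a saturated chain carbon bound to a sulfur, at the very same place in both pairs, so it is the same change. In the measured pair that change gave a number 5 percentage points lower from compound 1 to compound 2 (within the scatter). Compound 4 is therefore expected to give about 114% in this assay, because the same change gave a number 5 percentage points lower from compound 1 to compound 2 (within the scatter). The expected step is a number 5 percentage points lower from compound 3 to compound 4 (within the scatter). For compound 4 the expected range runs from 104% to 124%.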

Compound 4, a percentage reported as activity, at one dose (the size of the read-out at that dose, not a potency): 166%
Estimate against measurement, compound 4: 52 percentage points below, outside the stated range (above it).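

Going from propylsulfanyl to benzylsulfanyl with the fluoro group present gives a number 47 percentage points higher from compound 3 to compound 4 (beyond the scatter), and going from chloro to fluoro with benzylsulfanyl present gives a number 53 percentage points higher from compound 2 to compound 4 (beyond the scatter). In this assay, the effect of the sulfur substituent change depends on which halogen the core carries, so it cannot simply be carried from one core to the other: the same change on two cores in this assay, a number 5 percentage points lower (within the scatter) from compound 1 to compound 2 and a number 47 percentage points higher (beyond the scatter) from compound 3 to compound 4, 52 percentage points apart, beyond the scatter of two such steps. Going by these compounds alone, the halogen change likewise depends on the sulfur substituent, but these four compounds show only that the two changes do not add up independently, not why they fail to do so: the same change on two cores in this assay, a number 1 percentage points higher (within the scatter) from compound 1 to compound 3 and a number 53 percentage points higher (beyond the scatter) from compound 2 to compound 4, 52 percentage points apart, beyond the scatter of two such steps.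

As far as these compounds go, it remains open whether this jump needs the fluoro group specifically or would also appear with a methoxy group or a bromo group in the same place. A longer chain such as butyl on the sulfur, or an amine at the end of that chain, could show whether the phenyl ring itself is needed.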